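The compounds below may be only part of what the source reports. "The series", "measured", "known", "first", "only" and "open" are said of these compounds alone.

Measured compounds:
- compound 1 `CS(=O)(=O)OC1=CC(=O)c2ccccc2C1=O`: 7610 nM
- compound 2 `C=CCOc1ccc2c(c1)C(=O)C=CC2=O`: 27200 nM
- compound 3 `CCOc1ccc2c(c1)C(=O)C=CC2=O`: 25100 nM

In a functional assay on HeLa cells (Homo sapiens) for cytotoxicity (a higher number here means a weaker inhibitor, a lower number a stronger inhibitor), compound 1 gives the lowest of the three numbers. Its nearest neighbour is compound 3, which stands higher by a gap beyond the scatter, and compound 2 stands higher still, also beyond the scatter. Compounds 2 and 3 differ only in a 1.1-fold lower number from compound 2 to compound 3 (0.03 log units; within the scatter), a step that stays within the scatter.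

The compound not yet measured is compound 4 `O=C1C=C(Oc2cccs2)C(=O)c2ccccc21`. It differs from compound 1 in one place: thiophen-2-yl in place of methylsulfonyl on an oxygen on an unsaturated carbon.

Going by the values given here, none of the measured steps touches this place. Among the compounds with values here, the only step in hand, that from compound 2 to compound 3, concerns a saturated chain carbon bound to an oxygen on the aromatic ring, not the oxygen on the unsaturated carbon of the shared core, and it was within the scatter. There is therefore no measured guide for swapping (methylsulfonyl)oxy for (thiophen-2-yl)oxy, and the expectation has to rest on the value of compound 1 alone, with a wide range. The step from compound 1 to compound 4 is expected to be a 1.6-fold higher number from compound 1 to compound 4 (0.20 log units; within the scatter). Compound 4 is therefore estimated at 12000 nM in this assay, within a range from 3000 nM to 45000 nM.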

Compound 4, half-maximal inhibitory concentration: 35300 nM
Beside the measured number, compound 4's estimate is 2.9-fold (0.47 log units) below it; the measured number falls inside the stated range.
By their numbers in this assay, from the lowest: compound 1; then compounds 3, 2 and 4 (each within the scatter of the next).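

In this assay, going by these compounds alone, replacing methylsulfonyl with thiophen-2-yl on the oxygen on the unsaturated carbon gives a 4.6-fold higher number from compound 1 to compound 4 (0.67 log units; beyond the scatter) and this is the first measured evidence that the group at this position can change the result by more than the scatter. Within the data shown here, the only earlier step, a 1.1-fold lower number from compound 2 to compound 3 (0.03 log units; within the scatter), concerned a different place and stayed within the scatter, so it could not show this. Here, the sulfur-containing methylsulfonyl group with its two double bonds gives the lower number, but no measurement shown explains the difference.

A single pair cannot separate the effect of losing methylsulfonyl from the effect of gaining thiophen-2-yl, so neither group's contribution can be judged alone. From the compounds shown here alone, it remains open how this oxygen would fare when carrying other groups, such as acetyl, a phenyl ring or a longer chain ending in an amine, and whether any of them would give a number as low as that of compound 1 at 7610 nM.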